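This account rests on a few compounds, and the source may have more. Where it says the series, first, only, none or still open, it means among the compounds named here.

Measured in an ADME assay on MDBK cells (Bos taurus) for cytotoxicity; on this read-out higher numbers stand for lower toxicity in this test and lower numbers for higher toxicity in this test:
- Compound 1 `c1ccc(Cn2ccc3nc(-c4ccccc4)nc-3c2)cc1`: > 100000 nM (a limit)
- Compound 2 `N#Cc1ccc(Cn2ccc3nc(-c4ccccc4)nc-3c2)cc1`: > 100000 nM (a limit)

Neither entry is a number, so the two compounds can only be read against the limit of the assay. Compound 2 stands at > 100000 nM, which is a limit. The same holds for the whole small set: the limit of > 100000 nM in this assay, at which 2 of the 2 values shown sit.

The next compound, compound 3 `FC(F)(F)Oc1ccc(Cn2ccc3nc(-c4ccccc4)nc-3c2)cc1`, carries trifluoromethoxy in place of cyano on an aromatic carbon of a six-membered aromatic ring of carbon only, para to a large group (trifluoromethoxy in place of cyano on an aromatic carbon).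

Within the data shown here, the one measured step that bears on this change is a step that the two limits leave unreadable from compound 1 to compound 2. It offers no size to carry over and no direction. Among the measured compounds shown here, the only guide is that compound 1 and compound 2 both rest at the limit, so no step beyond the scatter is expected in this assay, and another limit reading is the likeliest outcome. The estimated step is a number no higher from compound 2 to compound 3 (the limit leaves the size open). For compound 3 the expected value is 100000 nM, with an estimated range from 40000 nM to 100000 nM.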

Compound 3, half-maximal cytotoxic concentration: 66000 nM
Compound 3: middle estimate off by 1.5-fold (0.18 log units), on the high side; measured number inside the range.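

In this assay, among these compounds, compound 3 gives 66000 nM, the only reading among the three compounds that is a number and not a limit, so a change on this aromatic carbon, para to a large group, can now be seen to bring a reading inside the range of the assay. Trifluoromethoxy in place of cyano gives an at least 1.5-fold lower number from compound 2 to compound 3 (0.18 log units; that floor lies within the scatter), and trifluoromethoxy in place of hydrogen gives an at least 1.5-fold lower number from compound 1 to compound 3 (0.18 log units; that floor lies within the scatter); these are floors and not sizes, and since both lie within the scatter, neither step alone establishes a real shift in toxicity in this test. The set as a whole therefore still sits mostly at one reading: the limit of > 100000 nM in this assay, at which 2 of the 3 values shown sit.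

As far as these compounds go, the true size of either step remains open, since the values of compound 1 and compound 2 are limits and only the floors can be read. Also open, from the compounds shown here alone, is whether an amine, a carboxylic acid or a longer chain on the same aromatic carbon would give a number or rest at the limit.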